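From Nitro to Fluoro on an Aromatic Carbon

A few compounds are considered here, and "the series" means these few. Any claim that something is new, unique, unknown or untested is made for them only; others in the source may bear on it.

In a functional assay on MIA PaCa-2 cells (Homo sapiens) for antiproliferative activity, read by sulforhodamine B assay, with a stated time of 48 h (on this read-out lower numbers stand for stronger inhibition and higher numbers for weaker inhibition), compound 3 (`COc1ccc2nc(-c3ccc(N/C=C\C(=O)c4ccc(OC)c([N+](=O)[O-])c4)cc3)sc2c1`) gives 23600 nM, level with compound 1 (`COc1ccc2nc(-c3ccc(N/C=C\C(=O)c4ccc(OC)c(O)c4)cc3)sc2c1`) at 21900 nM, while compound 2 (`COc1ccc2nc(-c3ccc(N/C=C\C(=O)c4ccc(OC)c(F)c4)c(C)c3)sc2c1`) gives a clearly lower 2300 nM. Compound 4 (`COc1ccc2nc(-c3ccc(N/C=C\C(=O)c4ccc(OC)c(F)c4)cc3)sc2c1`) arises from compound 3 through (fluoro in place of nitro on an aromatic carbon), fluoro in place of nitro on an aromatic carbon. Going by the values given here, the one measured step at this place, a 1.1-fold higher number from compound 1 to compound 3 (0.03 log units; within the scatter), put hydroxy and nitro within the scatter of each other. Compound 2 also carries the 3-fluoro-4-methoxyphenyl group, but differs elsewhere, so its 2300 nM is only a partial guide. A moderate fall is therefore expected, with an estimated 3.0-fold lower number from compound 3 to compound 4 (0.47 log units; beyond the scatter). The estimate in this assay for compound 4 is 8000 nM, with an expected range of 2500 nM to 25000 nM.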

Compound 4, half-maximal inhibitory concentration: 1300 nM
Compound 4: middle estimate off by 6.2-fold (0.79 log units), on the high side; measured number below the stated range.
By their numbers in this assay, from the lowest: compounds 4 and 2 (each within the scatter of the next); then compounds 1 and 3 (each within the scatter of the next).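

In this assay, this position proves sensitive to the group it carries: fluoro in place of nitro is a large step (an 18-fold lower number from compound 3 to compound 4 (1.26 log units; beyond the scatter)), and fluoro in place of hydroxy is one of similar size (a 17-fold lower number from compound 1 to compound 4 (1.23 log units; beyond the scatter)), although hydroxy and nitro had stood level. Compound 2 and compound 4, both with the 3-fluoro-4-methoxyphenyl group, lie within the scatter of each other (a 1.8-fold lower number from compound 2 to compound 4 (0.25 log units; within the scatter)), so the methyl group makes no readable difference here. On these data alone, whether an amine or a chlorine atom at this position would match fluoro remains open. Nothing shown here explains why fluoro stands apart.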